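The source may report more compounds than this note shows. Statements on the series, on what has been measured and on what is new or still open speak of the compounds shown alone.

Compound 1 `COC(=O)C(C)(C)Nc1cc(CS(=O)(=O)/C=C/c2c(OC)cc(OC)cc2OC)ccc1OC`: 2500 nM
Compound 2 `COC(=O)C(Nc1cc(CS(=O)(=O)/C=C/c2c(OC)cc(OC)cc2OC)ccc1OC)c1ccccc1`: 75 nM

Among the measured compounds shown here, in a functional assay on DU-145 cells (Homo sapiens) for cytotoxicity, read by trypan blue exclusion, with a stated time of 96 h (on this read-out lower numbers stand for stronger inhibition and higher numbers for weaker inhibition), compound 2 gives 75 nM, the lower of the two numbers so far. Compound 3 `COc1cc(OC)c(/C=C/S(=O)(=O)Cc2ccc(OC)c(NC(F)(F)C(=O)O)c2)c(OC)c1`, not yet measured, keeps the shared core and changes one place: carboxy(difluoro)methyl in place of methoxycarbonyl)(benzyl on a nitrogen on an aromatic ring. The entering carboxy(difluoro)methyl has no ring, whereas the leaving group has one six-membered aromatic ring.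

For the measured compounds named here, only one measured step bears on this nitrogen: a 33-fold lower number from compound 1 to compound 2 (1.52 log units; beyond the scatter). That large step shows that changing the group here can move the number far, but neither measured compound carries a carboxy group, so its size is only a rough guide. A sizeable step is therefore expected in this assay, most likely upward, since compound 2 already holds the lowest number. The estimated change is a 4.0-fold higher number from compound 2 to compound 3 (0.60 log units; beyond the scatter). For compound 3 the expected value is 300 nM, within an estimated range of 60 nM to 1500 nM.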

Compound 3, half-maximal inhibitory concentration: 150 nM
Compound 3: middle estimate off by 2.0-fold (0.30 log units), on the high side; low and high end bracket the measured number.
By their numbers in this assay, from the lowest: compounds 2 and 3 (each within the scatter of the next); then compound 1.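

In this assay, the step of a 2.0-fold higher number from compound 2 to compound 3 (0.30 log units; within the scatter) lies within the scatter, so the group of compound 2 and carboxy(difluoro)methyl cannot be told apart here, even though the entering group has no ring and carries a hydrogen-bond donor. This shows that a six-membered aromatic ring on this nitrogen is not needed for a number in this range, which the first two compounds alone could not show. The ringless 1-(methoxycarbonyl)-1-methylethyl group of compound 1 still stands well apart, with a 17-fold lower number from compound 1 to compound 3 (1.22 log units; beyond the scatter) beyond the scatter, so the absence of a ring does not by itself set the number, and nothing measured here explains the difference.

Still open is how much of the number of compound 3 goes with the carboxy group and how much with the two fluorine atoms: no compound shown changes only one of them. Also open, as far as these compounds go, is how an amine or a longer carbon chain on this nitrogen would read.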